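Swapping an aryl ether for a benzylamine on a diamine core

The source may report more compounds than this note shows. Statements on the series, on what has been measured and on what is new or still open speak of the compounds shown alone.

Compound 1 `Nc1cc(N)c2nc(-c3ccccc3)c(Oc3ccc(Cl)c(Cl)c3)nc2c1`: 29500 nM
Compound 2 `COc1cc(CNc2nc3cc(N)cc(N)c3nc2-c2ccccc2)cc(OC)c1OC`: 7940 nM
Compound 3 `CCOC(=O)[C@H](CCC(=O)O)NC(=O)c1ccc(Oc2nc3cc(N)cc(N)c3nc2-c2ccccc2)cc1`: a limit only, < 100000 nM

In a functional assay on SF-539 cells (Homo sapiens) for inhibition, read by sulforhodamine B assay, with a stated time of 48 h (on this read-out higher numbers stand for weaker inhibition of growth and lower numbers for stronger inhibition of growth), compound 1 stands at the highest of the two numbers reported; compound 2 gives a lower number, and the gap between them lies beyond the scatter. Compound 3 reaches only (the limit of < 100000 nM in this assay, at which 1 of the 3 values shown sits), so it offers no number to compare.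

Compound 4 `Nc1cc(N)c2nc(-c3ccccc3)c(NCc3ccc(F)cc3)nc2c1` differs from compound 1 in one place (4-fluorobenzyl)amino in place of 3,4-dichlorophenoxy on an aromatic carbon. Within the data shown here, no measured pair makes exactly this change, yet compound 2 also carries a benzylamino group at the same kind of aromatic carbon and gives the lower number of the two. A step downward beyond the scatter is therefore expected from compound 1 to compound 4 a 3.0-fold lower number from compound 1 to compound 4 (0.47 log units; beyond the scatter). Compound 4 is estimated at 10000 nM, with a range from 3000 nM to 35000 nM.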

Compound 4, concentration for total growth inhibition: 3550 nM
Estimate against measurement, compound 4: 2.8-fold (0.45 log units) above, and the stated range covers the measured number.
By their numbers in this assay, from the lowest: compound 4; then compound 2; then compound 1.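

With one change on an otherwise identical core, this assay gives an 8.3-fold lower number from compound 1 to compound 4 (0.92 log units; beyond the scatter), the first direct sign that the group on this aromatic carbon, next to the ring nitrogen, matters. The swap changes the link to the core and the halogens together, and it adds a hydrogen-bond donor, so the step cannot be assigned to any one of these. Nothing measured here explains the step. A (3,4-dichlorobenzyl)amino group would separate the link from the halogens. On these data alone, whether an anilino group or a longer chain fits this position remains open.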